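Pyrazoline series: trimethoxyphenyl replaces trifluoromethylphenyl

The compounds below may be only part of what the source reports. "The series", "measured", "known", "first", "only" and "open" are said of these compounds alone.

Compound 3 `COc1ccc(C2=NN(c3ccc(-c4ccccc4)nn3)C(c3ccc(C(F)(F)F)cc3)C2)cc1` stands second highest of the three numbers measured in a functional assay on MCF7 cells (Homo sapiens) for antiproliferative activity, read by MTT assay, with a stated time of 24 h; on this read-out higher numbers stand for weaker inhibition and lower numbers for stronger inhibition: in this assay compound 3 gives 46800 nM. Its nearest neighbour is compound 1 `COc1ccc(C2=NN(c3ccc(-c4ccccc4)nn3)C(c3ccc(Cl)cc3)C2)cc1`, which in this assay gives 58000 nM, and the gap a 1.2-fold lower number from compound 1 to compound 3 (0.09 log units; within the scatter) lies within the scatter. Furthest from it is compound 2 `COc1ccc(C2=NN(c3ccc(-c4ccccc4)nn3)C(c3ccc(F)cc3)C2)cc1`, which in this assay gives 20000 nM; the step of a 2.3-fold higher number from compound 2 to compound 3 (0.37 log units; beyond the scatter) is modest but beyond the scatter, as is a 2.9-fold lower number from compound 1 to compound 2 (0.46 log units; beyond the scatter).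

Compound 4 `COc1ccc(C2=NN(c3ccc(-c4ccccc4)nn3)C(c3cc(OC)c(OC)c(OC)c3)C2)cc1` differs from compound 3 by 3,4,5-trimethoxyphenyl in place of 4-(trifluoromethyl)phenyl on a saturated ring carbon. Within the data shown here, none of the measured steps exchanges the whole aryl group on that saturated ring carbon; all three only trade one substituent on the same ring for another, and all three are small. Among the measured compounds shown here, with no direct precedent, only a modest step is expected, and its direction is uncertain. In this assay compound 4 is expected to give about 25000 nM, between 8000 nM and 80000 nM, which would amount to a step of a 1.9-fold lower number from compound 3 to compound 4 (0.27 log units; within the scatter).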

Compound 4, half-maximal inhibitory concentration: 100000 nM
Compound 4: middle estimate off by 4.0-fold (0.60 log units), on the low side; the measured number lies above the stated range.
By their numbers in this assay, from the lowest: compound 2; then compounds 3, 1 and 4 (each within the scatter of the next, the first and the last beyond it).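

Exchanging the whole aryl group on this saturated ring carbon gives the largest step seen so far at this position in this assay, a 5.0-fold higher number from compound 2 to compound 4 (0.70 log units; beyond the scatter), and the trimethoxyphenyl group also falls on the weaker side of the trifluoromethyl compound, a 2.1-fold higher number from compound 3 to compound 4 (0.33 log units; beyond the scatter). The outcome depends on the group it is compared with, since a 1.7-fold higher number from compound 1 to compound 4 (0.24 log units; within the scatter) leaves compound 4 not separable from the chloro compound, so the added methoxy groups bring no gain over any of the three earlier compounds. Nothing available bears on why the 3,4,5-trimethoxyphenyl group behaves this way at this position.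

The compounds shown leave open whether all three methoxy groups are needed for this step or whether a ring with a single methoxy group would behave the same. Also open, on these data alone, is how a hydroxy group, an amine or a carboxylic acid on this aryl ring would read in this assay.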